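Swapping oxan-4-yl for isopropyl on a ring amine

The source may hold more compounds than are shown below. What is called first, only, known or untested is meant among the compounds shown, and "the series" means these compounds.

In a functional assay (strain AB) with Danio rerio as the target, read by microscopy, with a stated time of 1 h (a higher number here means that more compound is needed for the effect, a lower number that less compound is needed), compound 1 (`CC(C)(C)OC(=O)CCCCC[N+]1(C)CCc2c(sc(NC(=O)Nc3ccc(Cl)cc3)c2C(N)=O)C1`) gives 110 nM. Compound 2 (`NC(=O)c1c(NC(=O)Nc2ccc(Cl)cc2)sc2c1CCN(C1CCOCC1)C2`) gives 2830 nM, the higher of the two numbers, and the gap lies beyond the usual scatter. Compound 3 (`CC(C)N1CCc2c(sc(NC(=O)Nc3ccc(Cl)cc3)c2C(N)=O)C1`) has isopropyl in place of oxan-4-yl on an amine nitrogen in a ring. Within the data shown here, no measured pair shows what this swap does, so only a small shift in this assay seems reasonable. The expected step, a 1.6-fold lower number from compound 2 to compound 3 (0.20 log units; within the scatter), is toward a lower number but stays within the scatter. For compound 3 the estimate is 1800 nM, with an expected range of 500 nM to 5500 nM.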

Compound 3, half-maximal effective concentration: 1490 nM
Compound 3: the middle estimate sits 1.2-fold (0.08 log units) above what was measured; measured number inside the range.
By their numbers in this assay, from the lowest: compound 1; then compounds 3 and 2 (each within the scatter of the next).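

In this assay, the step is a 1.9-fold lower number from compound 2 to compound 3 (0.28 log units; within the scatter). On this amine nitrogen in a ring, then, oxan-4-yl with its ring and oxygen can give way to the smaller, ring-free isopropyl without a change beyond the scatter, so neither the ring nor the oxygen is shown to matter for this read-out. Nothing measured here bears on why the read-out holds.

As far as these compounds go, it remains open whether a group of another kind on this nitrogen, such as a carboxylic acid, a primary amine or a longer alkyl chain, would shift the number clearly. From the compounds shown here alone, whether this swap behaves the same way on a different core also remains open.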